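Shortening the acid-bearing chain of compound 2

The source may hold more compounds than are shown below. What is called first, only, known or untested is meant among the compounds shown, and "the series" means these compounds.

In a functional assay on Coronary artery (Bos taurus) (on this read-out lower numbers stand for an effect already at smaller amounts and higher numbers for an effect only at larger amounts of compound), compound 1 `CCCCCNC(=O)OCCCC/C=C\CCCCCCC(=O)O` gives 9300 nM and compound 2 `CCCCCNC(=O)NCCCCC#CCCCCCCC(=O)O` gives 3100 nM as its reading. Compound 2 therefore has the lower number of the two, and the gap between them lies beyond the usual scatter. Compound 3 `CCCCCNC(=O)NCCCCC#CCCC(=O)O` keeps the rest of compound 2 but carries carboxy in place of 4-carboxybutyl on a saturated chain carbon, two bonds along the chain from a triple-bonded carbon. For the measured compounds named here, no measured pair shows what this change does on its own, so any forecast is loose. In this assay a step toward a higher number, beyond the scatter, is expected, meaning an effect only at larger amounts. The estimated change is a 3.9-fold higher number from compound 2 to compound 3 (0.59 log units; beyond the scatter) on this reading. For compound 3 the expected value is 12000 nM with 3000 nM to 60000 nM as the estimated range.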

Compound 3, half-maximal effective concentration: > 10000 nM
Compound 3: a limit, no number (the forecaster's own chance of this, stated with the estimate: 25%); the middle value is on the limit's open side.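

For the compounds shown here, this is the first measured change at this position, and shortening the acid-bearing chain moves the reading toward larger amounts: carboxy in place of 4-carboxybutyl, on a saturated chain carbon, two bonds along the chain from a triple-bonded carbon, gives an at least 3.2-fold higher number from compound 2 to compound 3 (0.50 log units; beyond the scatter). In this assay compound 3 gives > 10000 nM, which is a limit of the assay and not a number. The step therefore has a lower bound but no upper one, and its true size stays unknown: the limit of > 10000 nM in this assay, at which 1 of the 3 values shown sits.

As far as these compounds go, only 4-carboxybutyl and carboxy are compared here, so it stays open whether a 2-carboxyethyl group, of intermediate length, would read closer to compound 2 or to compound 3. Also open, from the compounds shown here alone, is what a chain longer than 4-carboxybutyl would do with the rest of compound 2 unchanged.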